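Swapping a Dihydroxy Chain on Compound 1

The compounds below may be only part of what the source reports. "The series", "measured", "known", "first", "only" and "open" are said of these compounds alone.

Values measured so far in a physicochemical assay for lipophilicity, read by HPLC, measured as octanol-water partition; on this read-out higher numbers stand for higher lipophilicity and lower numbers for lower lipophilicity:
Compound 1 `CC(C)(O)C(O)Cc1c(O)cc(/C=C/c2ccc(O)cc2)cc1O` gives 1.59
Compound 2 `CC(C)(O)C(O)Cc1c(O)cc(/C=C/c2ccccc2)cc1O` gives 2.59
Compound 3 `CC1(C)C=Cc2c(O)cc(/C=C/c3ccc(O)cc3)cc2O1` gives 3.34

Of these three numbers, compound 1 has the lowest at 1.59 and serves as the starting point here. Compound 4 `CC(C)=CCc1c(O)cc(/C=C/c2ccc(O)cc2)cc1O` has not yet been measured in this assay and differs from compound 1 in one place: 2-methylprop-1-en-1-yl in place of 1,2-dihydroxy-2-methylpropyl on a saturated chain carbon bound to an aromatic carbon. Put simply, 2-methylprop-1-en-1-yl stands in place of 1,2-dihydroxy-2-methylpropyl on a saturated chain carbon bound to an aromatic carbon.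

Among the compounds with values here, only one measured step offers a direct comparison, and it lies elsewhere in the molecule. That step, a number 1.00 log units higher from compound 1 to compound 2 (beyond the scatter), came with hydrogen in place of hydroxy on an aromatic carbon. The change to compound 4 also removes hydroxy groups, here those of the chain, and the group that enters carries none. Compound 3 also lacks the dihydroxy chain and reads 3.34 as a second guide. The step expected is therefore a number 2.01 log units higher from compound 1 to compound 4 (beyond the scatter), which would be larger than the measured step and in the same direction. For compound 4 the expected value is 3.6, with an estimated range from 3 to 4.2.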

Compound 4, partition coefficient: 2.56
The estimate for compound 4 lay 1.04 log units above the measured number; measured number outside the range, below it.
By their numbers in this assay, from the lowest: compound 1; then compounds 4 and 2 (each within the scatter of the next); then compound 3.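

Within the data shown here, the chain on the saturated carbon bound to an aromatic carbon now has a measured step of its own in this assay, where the read-out is a number 0.97 log units higher from compound 1 to compound 4 (beyond the scatter) for this one swap, whereas the only earlier step came from a change on an aromatic carbon. The swap is a bundle of differences rather than a single one: 1,2-dihydroxy-2-methylpropyl, with 6 heavy atoms and 2 hydrogen-bond donors, gives way to 2-methylprop-1-en-1-yl, with 4 heavy atoms, no hydrogen-bond donors and 1 double bond, and this single pair cannot show how much of the step belongs to each difference. No measurement is available that explains the size of this step.

On these data alone, it remains open how the read-out would respond at this place to a chain keeping just one hydroxy group, to a saturated 3-methylbutyl chain, or to a chain ending in an amine or a carboxylic acid. As far as these compounds go, it is also open whether the same swap would give a similar step on the core of compound 2.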